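The compounds below may be only part of what the source reports. "The series", "measured", "known", "first", "only" and "open" are said of these compounds alone.

This set comes from an ADME assay on HEL cells (Homo sapiens) for cytotoxicity, with a stated time of 3 days; on this read-out higher numbers stand for lower toxicity in this test and lower numbers for higher toxicity in this test. Compound 1 has the structure `CCC1(Cc2ccccc2)OS(=O)(=O)C=C1OCc1ccc([N+](=O)[O-])cc1`. In this assay compound 1 gives >= 80000 nM, which is a limit of the assay rather than a measured number, as the limit of >= 80000 nM in this assay, at which 1 of the 3 values shown sits, shows. Two further compounds share the same core. Compound 2 is `CCC1(Cc2ccccc2)OS(=O)(=O)C=C1OCCCCCCc1ccccc1`. In this assay compound 2 gives >= 20000 nM, again a limit, matching (the limit of >= 20000 nM in this assay, at which 1 of the 3 values shown sits). Compound 3 is `CC1(C(c2ccccc2)c2ccccc2)OS(=O)(=O)C=C1OCc1ccccc1`. In this assay compound 3 gives >= 400000 nM, also a limit, matching (the limit of >= 400000 nM in this assay, at which 1 of the 3 values shown sits). Since every known value is a limit, no step between any two of these compounds can be sized, and none can be ranked against another.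

Compound 4, `CCC1(Cc2ccccc2)OS(=O)(=O)C=C1OCc1ccc(F)cc1`, has not yet been measured. It differs from compound 1 at a single place: fluoro in place of nitro on an aromatic carbon. Among the measured compounds shown here, with all known values being limits, there is no measured step to draw on for the size of this change. A step of no more than the usual scatter is expected, with no direction favored. Compound 4 is therefore estimated at 100000 nM in this assay, within 20000 nM to 400000 nM. The expected step this implies is a step that the limit leaves unreadable from compound 1 to compound 4, and the assay may well report only a limit once more.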

Compound 4, minimum cytotoxic concentration: >= 50000 nM
Compound 4: only a limit was reported; the forecaster's own chance of this, stated with the estimate: 75%; the middle value does not contradict the limit.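

Among the compounds shown here, compound 1 and compound 4 are both reported in this assay only as limits, not as measured numbers, so no step between them can be read. The compounds shown leave open whether fluoro in place of nitro on an aromatic carbon changes the minimum cytotoxic concentration at all, and if so, in which direction and by how much.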